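A few compounds are considered here, and "the series" means these few. Any claim that something is new, unique, unknown or untested is made for them only; others in the source may bear on it.

Three ureas built on one shared core have numbers in a functional assay on Shh Light II cells (Mus musculus) for inhibition, read by a luciferase reporter; a higher number here means a weaker inhibitor, a lower number a stronger inhibitor. Compound 1 `CC(C)c1ccccc1NC(=O)N1CCC(c2nc(-c3ccc4ccccc4n3)no2)CC1` gives 480 nM. Compound 2 `O=C(N1CCC(c2nc(-c3ccc4ccccc4n3)no2)CC1)N1CCCc2ccccc21` gives 2300 nM. Compound 3 `O=C(Nc1ccccc1C(F)(F)F)N1CCC(c2nc(-c3ccc4ccccc4n3)no2)CC1` gives 700 nM. Compound 3 thus stands second highest of the three: its nearest neighbour is compound 1, with a 1.5-fold higher number from compound 1 to compound 3 (0.16 log units; within the scatter), a step within the scatter, and its furthest is compound 2, with a 3.3-fold lower number from compound 2 to compound 3 (0.52 log units; beyond the scatter), a step beyond the scatter. The step of a 4.8-fold higher number from compound 1 to compound 2 (0.68 log units; beyond the scatter) points the same way. Taken together, exchanging one substituent on the phenyl for another leaves the number essentially unchanged, whereas replacing the arylamino by 1,2,3,4-tetrahydroquinolin-1-yl at the carbonyl costs modestly.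

Compound 4 `O=C(NC1CCCCC1)N1CCC(c2nc(-c3ccc4ccccc4n3)no2)CC1` is not yet measured. Its change from compound 3 is cyclohexyl in place of 2-(trifluoromethyl)phenyl on an amide-type nitrogen. For the measured compounds named here, no measured step exchanges an aromatic ring for a non-aromatic one on this nitrogen, so the two phenyl-substituent steps bear only loosely, and the steps through compound 2 set the scale of what a larger change at the carbonyl has cost. The amide hydrogen is retained. A modest weakening is therefore expected, a 1.7-fold higher number from compound 3 to compound 4 (0.23 log units; within the scatter), with wide uncertainty. Compound 4 is estimated at 1200 nM, between 400 nM and 4000 nM.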

Compound 4, half-maximal inhibitory concentration: 57 nM
For compound 4 the middle estimate is 21-fold (1.32 log units) above the measured one, and the stated range ends above it.
By their numbers in this assay, from the lowest: compound 4; then compounds 1 and 3 (each within the scatter of the next); then compound 2.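

Working notes on the series: at the amide-type nitrogen, an aromatic ring is not needed for activity in this assay. Cyclohexyl in place of 2-(trifluoromethyl)phenyl gives a 12-fold lower number from compound 3 to compound 4 (1.09 log units; beyond the scatter), and cyclohexyl in place of 2-isopropylphenyl gives an 8.4-fold lower number from compound 1 to compound 4 (0.93 log units; beyond the scatter), whereas the exchange of substituents on the phenyl had stayed within the scatter, making the ring type at this nitrogen a far stronger lever than the earlier compounds showed. Cyclohexylamino in place of 1,2,3,4-tetrahydroquinolin-1-yl on the carbonyl carbon gives a 40-fold lower number from compound 2 to compound 4 (1.61 log units; beyond the scatter), which makes this single site span the full range of the four numbers and leaves compound 4 the strongest inhibitor of the set. Nothing available accounts for the size of these steps.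

As far as these compounds go, it remains open whether the gain belongs to non-aromatic rings generally or to cyclohexyl in particular, a question that cyclopentyl, cycloheptyl, an open chain such as n-hexyl or an unsubstituted phenyl on this nitrogen would help settle. The role of the amide hydrogen also stays unresolved, and a methyl on that nitrogen with the cyclohexyl kept in place would isolate it.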